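Trimethoxyphenyl Core Analogues: Indole Swapped for Methylindazole

The compounds below may be only part of what the source reports. "The series", "measured", "known", "first", "only" and "open" are said of these compounds alone.

Measured compounds, in a functional assay on HeLa cells (Homo sapiens) for inhibition, read by CCK-8 assay, with a stated time of 48 h; on this read-out lower numbers stand for stronger inhibition and higher numbers for weaker inhibition:
- Compound 1, `COc1cc(-c2ccnc3cc(-c4c[nH]c5ccccc45)nn23)cc(OC)c1OC`: 195 nM
- Compound 2, `COc1cc(-c2ccnc3cc(-c4ccc(C(F)(F)F)cc4)nn23)cc(OC)c1OC`: 1840 nM
- Compound 3, `COc1cc(-c2ccnc3cc(-c4cccc(C)c4)nn23)cc(OC)c1OC`: 4230 nM

Compound 1 gives the lowest number of the three, so it is the strongest inhibitor here; both other compounds lie beyond the scatter from it. Replacing its 1H-indol-3-yl group by a single six-membered ring cost potency in each case: a 9.4-fold higher number from compound 1 to compound 2 (0.97 log units; beyond the scatter) and a 22-fold higher number from compound 1 to compound 3 (1.34 log units; beyond the scatter). Between the two six-membered rings the gap was smaller, a 2.3-fold higher number from compound 2 to compound 3 (0.36 log units; beyond the scatter).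

Compound 4, `COc1cc(-c2ccnc3cc(-c4ccc5cnn(C)c5c4)nn23)cc(OC)c1OC`, has not yet been measured in this assay . It differs from compound 1 in one place: 1-methyl-1H-indazol-6-yl in place of 1H-indol-3-yl on an aromatic carbon. The entering group keeps a five-membered ring joined to a six-membered ring of carbon only, as the leaving group did, but it carries no hydrogen-bond donor and has two hydrogen-bond acceptors instead. The two measured steps from compound 1 both show that losing the 1H-indol-3-yl group weakens inhibition, though neither of them kept a two-ring group, so they bear on this step only in part. Compound 4 is therefore expected to fall between compound 1 and compound 2, with a step of a 3.1-fold higher number from compound 1 to compound 4 (0.49 log units; beyond the scatter). The estimate for compound 4 is 600 nM, within a range from 200 nM to 2000 nM.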

Compound 4, half-maximal inhibitory concentration: 97 nM
Compound 4: middle estimate off by 6.2-fold (0.79 log units), on the high side; measured number outside the range, below it.
By their numbers in this assay, from the lowest: compounds 4 and 1 (each within the scatter of the next); then compound 2; then compound 3.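

In this assay, putting 1-methyl-1H-indazol-6-yl in place of 1H-indol-3-yl gives a 2.0-fold lower number from compound 1 to compound 4 (0.30 log units; within the scatter), so the two groups cannot be told apart at this position, even though the entering group has 0 hydrogen-bond donors where the leaving group had 1. For the compounds shown here, this pair therefore shows that a hydrogen-bond donor on this group is not needed to keep inhibition in this range, which the earlier compounds could not show because neither of their replacements kept a two-ring group. The new group also stands well clear of both single-ring groups, with a 19-fold lower number from compound 2 to compound 4 (1.28 log units; beyond the scatter) and a 44-fold lower number from compound 3 to compound 4 (1.64 log units; beyond the scatter), so among these four compounds both two-ring groups lie beyond the scatter from both single-ring groups, and no compound goes against this; nothing measured here explains this pattern.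

The compounds shown leave open whether two joined rings are enough on their own, which a naphthalen-2-yl group, made of carbon only, would test. They also leave open whether the methyl on the indazole matters, which replacing it with a hydrogen or a longer chain such as propyl would begin to answer.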